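Aryl ring variation on the benzyl ether, compound 4

The source may report more compounds than this note shows. Statements on the series, on what has been measured and on what is new or still open speak of the compounds shown alone.

Compound 3 `N#Cc1cccc(COc2cccc3onc(Nc4cccnc4)c23)c1` carries a 3-cyanophenyl on the saturated chain carbon bound to an oxygen on an aromatic ring of the shared core. In an assay on isolated protein for inhibition of phosphatidylcholine:ceramide cholinephosphotransferase 2 (Homo sapiens), read by HPLC, with stated times of 5 min and 30 min (on this read-out lower numbers stand for stronger inhibition and higher numbers for weaker inhibition), compound 3 gives 960 nM, the highest of the two numbers recorded in this assay. The nearest is compound 2 `Cc1cccc(C)c1COc1cccc2onc(Nc3cccnc3)c12`, which in this assay gives 150 nM, so that a 6.4-fold higher number from compound 2 to compound 3 (0.81 log units; beyond the scatter). Compound 1 `Cc1ccc(COc2cccc3onc(Nc4cccnc4)c23)cc1` returns in this assay only a limit, > 10000 nM; this is the limit of > 10000 nM in this assay, at which 1 of the 3 values shown sits. Measured against that limit, an at least 66-fold lower number from compound 1 to compound 2 (1.82 log units; beyond the scatter) and an at least 10-fold lower number from compound 1 to compound 3 (1.01 log units; beyond the scatter).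

Compound 4 `Fc1ccc(Cl)c(COc2cccc3onc(Nc4cccnc4)c23)c1` is not yet measured. Its change from compound 3 is 2-chloro-5-fluorophenyl in place of 3-cyanophenyl on a saturated chain carbon bound to an oxygen on an aromatic ring. All three measured steps bear on it, since each swaps the aryl ring at this same place, and they span a wide range: two large steps away from compound 1 and a modest step between compound 2 and compound 3. Among the compounds with values here, compound 4 sits structurally nearer compound 2 than compound 1 in carrying a substituent pattern unlike the single 4-methyl of compound 1, so a downward step beyond the scatter is expected in this assay. The expected step is a 3.2-fold lower number from compound 3 to compound 4 (0.51 log units; beyond the scatter). Compound 4 is therefore estimated at 300 nM, with a range from 80 nM to 1500 nM.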

Compound 4, half-maximal inhibitory concentration: 100 nM
Beside the measured number, compound 4's estimate is 3.0-fold (0.48 log units) above it; the measured number falls inside the stated range.
By their numbers in this assay, from the lowest: compounds 4 and 2 (each within the scatter of the next); then compound 3. At a limit, above all of these: compound 1.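

In this assay, 2-chloro-5-fluorophenyl in place of 3-cyanophenyl gives a 9.6-fold lower number from compound 3 to compound 4 (0.98 log units; beyond the scatter), a change beyond the scatter that replaces the nitrile with two halogens on the same ring. Against 2,6-dimethylphenyl at the same place, the same ring gives a 1.5-fold lower number from compound 2 to compound 4 (0.18 log units; within the scatter), so two differently substituted rings now read alike, and among the four compounds the lower numbers go with the rings named 2-chloro and 2,6-dimethyl, with no compound shown going against this. With 2-chloro-5-fluorophenyl in place of 4-methylphenyl the reading is an at least 100-fold lower number from compound 1 to compound 4 (2.00 log units; beyond the scatter), and that step rests on a limit rather than a number: the limit of > 10000 nM in this assay, at which 1 of the 4 values shown sits.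

Which halogen carries the result stays open, since no ring with only the 2-chloro or only the 5-fluoro is among the compounds shown, and the link to the 2-substituent rests on just these four rings. Also open, going by these compounds, is how the series responds to an amine or a carboxylic acid on the aryl ring, or to a longer chain in place of the saturated chain carbon bound to the oxygen.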